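The source may report more compounds than this note shows. Statements on the series, on what has been measured and on what is new or still open speak of the compounds shown alone.

Of the compounds shown here, three of one shared core have been measured in a functional assay on C6 cells (Rattus norvegicus) for cytotoxicity, read by MTT assay, with a stated time of 24 h, tested at 100 ug/mL; on this read-out higher numbers stand for a weaker effect at the one concentration tested and lower numbers for a stronger effect. Compound 1 `Cc1nnc(SCC(=O)N/N=c2/scc(-c3ccccc3)n2-c2ccccc2)s1` gives 61.8%, and compound 2 `Cn1nnnc1SCC(=O)N/N=c1/scc(-c2ccc([N+](=O)[O-])cc2)n1-c1ccccc1` gives 64.1%. Compound 3 `O=C(CSc1nnnn1-c1ccccc1)N/N=c1/scc(-c2ccccc2)n1-c1ccccc1` gives 35.8%, the lowest of the three numbers; its gap to compound 1 and its gap to compound 2 both lie beyond the scatter. Within the data shown here, the only measured step between compounds that differ in a single place runs a number 26 percentage points lower from compound 1 to compound 3 (beyond the scatter), with 1-phenyl-1H-tetrazol-5-yl in place of 5-methyl-1,3,4-thiadiazol-2-yl on a sulfur.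

Compound 4 `Cn1nnnc1SCC(=O)N/N=c1/scc(-c2ccccc2)n1-c1ccccc1` has not yet been measured. It differs from compound 3 in one place: methyl in place of phenyl on an aromatic nitrogen. Among the measured compounds shown here, no measured step isolates this change. For the measured compounds named here, compound 2 carries the same 1-methyl-1H-tetrazol-5-yl group, but it also carries a nitro group that compound 4 lacks, so its value shows only that a compound bearing that group can give a high number in this assay. The step from compound 1 to compound 3 shows that a change in the ring borne on the sulfur can shift the number by a modest amount. The step to compound 4 is therefore expected to be upward, about a number 19.2 percentage points higher from compound 3 to compound 4 (beyond the scatter). The estimate for compound 4 is 55%, with a range from 38% to 72%.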

Compound 4, a percentage reported as activity, at one concentration (the size of the read-out at that concentration, not a potency): 38.8%
The estimate for compound 4 lay 16.2 percentage points above the measured number, within the range that was stated.
By their numbers in this assay, from the lowest: compounds 3 and 4 (each within the scatter of the next); then compounds 1 and 2 (each within the scatter of the next).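

In this assay the exchange on the aromatic nitrogen reads a number 3 percentage points higher from compound 3 to compound 4 (within the scatter) and so leaves compound 3 and compound 4 apart by no more than the scatter, which shows that at this position the low number does not depend on the phenyl group and its six-membered aromatic ring, since a methyl group serves equally. Among these compounds, the step of a number 23 percentage points lower from compound 1 to compound 4 (beyond the scatter) repeats with 1-methyl-1H-tetrazol-5-yl what had been seen only with 1-phenyl-1H-tetrazol-5-yl, so both of these groups on the sulfur give lower numbers than 5-methyl-1,3,4-thiadiazol-2-yl, with compound 2 going against this pattern as long as it keeps its nitro group. The step of a number 25.3 percentage points lower from compound 2 to compound 4 (beyond the scatter) then ties the high number of compound 2 to the nitro group on the aromatic carbon rather than to the 1-methyl-1H-tetrazol-5-yl group.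

The data shown offer no explanation for any of these differences. Going by these compounds, it remains open whether an ethyl group, a longer chain, an amine or a carboxylic acid at the same aromatic nitrogen would stay level with compound 3 and compound 4, and whether a nitro group would raise the number of compound 3 as well.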